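This account rests on a few compounds, and the source may have more. Where it says the series, first, only, none or still open, it means among the compounds named here.

The study compares three measured anilino-heterocycles and one that has not yet been tested. Compound 1 `CCCc1ccc(Nc2nccs2)cc1OCC=C(C)C` gives 23000 nM in a functional assay on MT2 cells (Homo sapiens) for cytotoxicity (on this read-out lower numbers stand for higher toxicity in this test and higher numbers for lower toxicity in this test), and compound 3 `CC(C)=CCOc1cc(Nc2nccs2)ccc1C` gives 17000 nM, the two lying within the scatter of each other, as the step of a 1.4-fold lower number from compound 1 to compound 3 (0.13 log units; within the scatter) shows. Compound 2 `CC(C)=CCOc1cc(Nc2ncccn2)ccc1Cl` gives 2500 nM, the lowest number of the three; its steps to compound 3 and to compound 1 both lie beyond the scatter, so compound 2 is the most toxic of the measured set.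

Compound 4 `CC(C)=CCOc1cc(Nc2nccc(C)n2)ccc1Cl` differs from compound 2 by one change: methyl in place of hydrogen on an aromatic carbon, that is, pyrimidin-2-yl becomes 4-methylpyrimidin-2-yl. Among the measured compounds shown here, no measured step touches this ring; the only single-point step on record, from compound 1 to compound 3, alters a saturated chain carbon and stays within the scatter, so it carries no direct lesson for the new position. With nothing pointing either way, the expectation for compound 4 is a step no larger than the scatter, no change at the digits printed from compound 2 to compound 4 (within the scatter). Compound 4 is therefore estimated at 2500 nM, within a range from 900 nM to 7000 nM.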

Compound 4, half-maximal cytotoxic concentration: < 200 nM
Compound 4: no number, only a limit (the forecaster's own chance of this, stated with the estimate: 10%); middle value at least 12-fold (1.09 log units) away from the limit.
By their numbers in this assay, from the lowest: compound 2; then compounds 3 and 1 (each within the scatter of the next). At a limit, below all of these: compound 4.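

Methyl in place of hydrogen at this position, on an aromatic carbon next to the ring nitrogen, makes a large difference: in this assay there is an at least 12-fold lower number from compound 2 to compound 4 (1.09 log units; beyond the scatter), so a single added heavy atom leaves compound 4 clearly more toxic in this test. Among the compounds shown here, compound 4 has no exact number, only a limit of the assay, so the full size of this step stays unknown: the limit of < 200 nM in this assay, at which 1 of the 4 values shown sits. The only earlier single-place step, a 1.4-fold lower number from compound 1 to compound 3 (0.13 log units; within the scatter), lay on a saturated chain carbon, so the change from pyrimidin-2-yl to 4-methylpyrimidin-2-yl is the first to show that one small group can shift this read-out beyond the scatter.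

The compounds shown leave open whether an ethyl, a methoxy or an amine at this position would shift the number as methyl does. They also leave open whether a methyl would count in the same way on the ring carrying the nitrogen in compound 3.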